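Swapping a Four-Membered Ring for a Substituted Five-Membered One

The compounds below may be only part of what the source reports. "The series", "measured", "known", "first", "only" and "open" are said of these compounds alone.

Of the compounds shown here, three sharing one core have been measured in an assay on isolated protein for displacement of a labelled ligand from melanin-concentrating hormone receptor 1 (Homo sapiens); a lower number here means a stronger inhibitor, a higher number a weaker inhibitor. Compound 1 `O=C(CCc1ccc(C(F)(F)F)cc1)Nc1ccc2nc(N3CCC3)ccc2c1` gives 4 nM, the lowest of the three numbers. Compound 2 `CC1CCCN1c1ccc2cc(NC(=O)CCc3ccc(C(F)(F)F)cc3)ccc2n1` gives 5 nM, and compound 3 `Nc1ccc2cc(NC(=O)CCc3ccc(C(F)(F)F)cc3)ccc2n1` gives 240 nM. The step of a 1.3-fold higher number from compound 1 to compound 2 (0.10 log units; within the scatter) shows that enlarging the saturated ring barely moves this assay, whereas the steps of a 60-fold higher number from compound 1 to compound 3 (1.78 log units; beyond the scatter) and a 48-fold higher number from compound 2 to compound 3 (1.68 log units; beyond the scatter) show a large loss when the ring is replaced by a bare amino group.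

Compound 4 `CC(=O)NC1CCN(c2ccc3cc(NC(=O)CCc4ccc(C(F)(F)F)cc4)ccc3n2)C1` has not yet been measured. It differs from compound 1 in one place: 3-acetamidopyrrolidin-1-yl in place of azetidin-1-yl on an aromatic carbon. The saturated ring on the aromatic carbon is kept, so the large loss seen for compound 3 is not expected; the nearer guide is the small step from compound 1 to compound 2, with some allowance for the acetamido group. For compound 4 a modest weakening is expected, a 2.0-fold higher number from compound 1 to compound 4 (0.30 log units; within the scatter), giving an estimate of 8 nM with a range from 2 nM to 40 nM.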

Compound 4, half-maximal inhibitory concentration: 5 nM
Beside the measured number, compound 4's estimate is 1.6-fold (0.20 log units) above it, within the range that was stated.
By their numbers in this assay, from the lowest: compounds 1, 2 and 4 (each within the scatter of the next); then compound 3.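

In this assay, the position next to the ring nitrogen tolerates much more than the small rings of compound 1 and compound 2 could show: the larger 3-acetamidopyrrolidin-1-yl group stays within the scatter on both comparisons (a 1.3-fold higher number from compound 1 to compound 4 (0.10 log units; within the scatter); no change at the digits printed from compound 2 to compound 4 (within the scatter)). Compared with the bare amino group, the same group gives a large gain (a 48-fold lower number from compound 3 to compound 4 (1.68 log units; beyond the scatter)), so the large loss seen with the amino group does not return when an acetamido group is carried on the saturated ring. No measurement at hand explains why this added group leaves the number within the scatter.

As far as these compounds go, it remains open whether this tolerance extends to other groups on the five-membered ring. A free amine or a carboxylic acid in place of the acetamido group would test this, as would a longer chain.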